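The source may report more compounds than this note shows. Statements on the series, on what has been measured and on what is new or still open speak of the compounds shown alone.

Compounds measured so far:
compound 1, `Nc1cc(-c2nc(C(c3ccc(F)cc3)c3ccc(F)cc3)sc2CC(=O)O)cc(F)n1`: 30%
compound 2, `O=C(O)Cc1sc(C(c2ccc(F)cc2)c2ccc(F)cc2)nc1-c1cn[nH]c1`: 80%

In an in vitro functional assay on HEK285-7 cells for antagonist activity at prostaglandin D2 receptor 2 (Homo sapiens), read by BRET and beta-arrestin recruitment (on this read-out lower numbers stand for smaller maximal responses and higher numbers for larger maximal responses), compound 2 gives 80%, the higher of the two numbers recorded, and its nearest neighbour, compound 1, gives 30%. Among the compounds with values here, the one step measured so far, a number 50 percentage points higher from compound 1 to compound 2 (beyond the scatter), is large. Compound 3, `O=C(O)Cc1sc(C(c2ccc(F)cc2)c2ccc(F)cc2)nc1-c1ccnc(N2CCC2)c1`, has not yet been tested. The change from compound 2 to compound 3 is 2-(azetidin-1-yl)pyridin-4-yl in place of 1H-pyrazol-4-yl on an aromatic carbon. It bears on the measured step, in that both compound 1 and compound 3 carry a pyridin-4-yl group at this place, whereas compound 2 carries a 1H-pyrazol-4-yl. Since the move from the pyridinyl of compound 1 to the pyrazolyl of compound 2 brought a number 50 percentage points higher from compound 1 to compound 2 (beyond the scatter), the return to a pyridinyl, though with an azetidin-1-yl in place of the amino group and without the fluorine, is expected to lower the response, with a step of about a number 35 percentage points lower from compound 2 to compound 3 (beyond the scatter). Compound 3 is therefore estimated at 45% in this assay, within 20% to 75%.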

Compound 3, largest response reached (reported as efficacy), in percent of the reference or control that the assay uses: 80%
Beside the measured number, compound 3's estimate is 35 percentage points below it, and the stated range ends below it.
By their numbers in this assay, from the lowest: compound 1; then compounds 2 and 3 (each within the scatter of the next).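

In this assay, the 2-(azetidin-1-yl)pyridin-4-yl group in place of 1H-pyrazol-4-yl gives no change at the digits printed from compound 2 to compound 3 (within the scatter), so this position takes a six-membered aromatic ring and a group of 10 heavy atoms without the low number seen for compound 1. Between the two pyridin-4-yl groups, 2-(azetidin-1-yl)pyridin-4-yl in place of 2-amino-6-fluoropyridin-4-yl gives a number 50 percentage points higher from compound 1 to compound 3 (beyond the scatter), which shows that the pyridin-4-yl ring alone does not set the low number and that its substituents matter. Nothing shown here accounts for either result.

This last change alters the amino group and the fluorine together, so the compounds leave open which of them goes with the low number of compound 1. A 2-aminopyridin-4-yl group without the fluorine, or a 2-(azetidin-1-yl)-6-fluoropyridin-4-yl group, would separate the two.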